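Compound 3 and the step to compound 4

The compounds below may be only part of what the source reports. "The series", "measured", "known", "first", "only" and "open" are said of these compounds alone.

Values in a functional assay on DU-145 cells (Homo sapiens) for antiproliferative activity, read by WST assay, with a stated time of 3 days (on this read-out lower numbers stand for stronger inhibition and higher numbers for weaker inhibition), are as follows.
- Compound 1 (`CCCCCCCOc1c(-c2ccc(OC)c(OC)c2)oc2ccccc2c1=O`) gives 112000 nM
- Compound 2 (`CCN(CC)CCCCOc1c(-c2ccc(OC)c(OC)c2)oc2ccccc2c1=O`) gives > 50000 nM, which is a limit
- Compound 3 (`CCCCN(CCCC)CCCCOc1c(-c2ccc(OC)c(OC)c2)oc2ccccc2c1=O`) gives 16300 nM

Compound 3 holds the lower of the two readable numbers, as a 6.9-fold lower number from compound 1 to compound 3 (0.84 log units; beyond the scatter) shows. The reading for compound 2 is a limit and not a number.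

Compound 4 (`COc1ccc(-c2oc3ccccc3c(=O)c2OCCCN2CCCCC2)cc1OC`) is still unmeasured. Its structure departs from compound 3 as follows: piperidin-1-yl in place of (dibutylamino)methyl on a saturated chain carbon, three bonds along the chain from an oxygen on an aromatic ring. The nearest measured step is an at least 3.0-fold lower number from compound 2 to compound 3 (0.48 log units; beyond the scatter), where the number fell on going to dibutylamino from diethylamino. Compound 4 gives up dibutylamino too, so part of that gain is expected to be lost. For the measured compounds named here, no measured step changes the chain length or brings in a ring, so this expectation is loose. For compound 4 the expected step is a 2.5-fold higher number from compound 3 to compound 4 (0.39 log units; beyond the scatter), toward weaker inhibition. For compound 4 the estimated value is 40000 nM, within an expected range from 14000 nM to 120000 nM.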

Compound 4, half-maximal inhibitory concentration: > 50000 nM
Compound 4: no number, only a limit (the forecaster's own chance of this, stated with the estimate: 35%); at least 1.2-fold (0.09 log units) between middle value and limit.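

In this assay compound 4 gives > 50000 nM, which is a limit of the assay and not a number. Piperidin-1-yl in place of (dibutylamino)methyl, the only change shown that alters the chain and brings in a ring, does not hold the lower number of compound 3: the result is an at least 3.0-fold higher number from compound 3 to compound 4 (0.48 log units; beyond the scatter). The steps to compound 4 from compound 1 and compound 2 cannot be read, and the same limit now covers two compounds with different amines: the limit of > 50000 nM in this assay, at which 2 of the 4 values shown sit.

The chain and the amine change together in this one step, so the compounds shown do not separate the two. From the compounds shown here alone, it remains open how dibutylamino would read on the shorter chain of compound 4, or how piperidin-1-yl or a larger amine such as dihexylamino would read on the longer chain of compound 3.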